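The source may report more compounds than this note shows. Statements on the series, on what has been measured and on what is new or still open speak of the compounds shown alone.

Of the compounds shown here, two have been measured so far in a functional assay for inhibition, with Rattus norvegicus as the target; a lower number here means a stronger inhibitor, a higher number a weaker inhibitor. Compound 1 `Cc1ccc(C(C)/N=c2\c(O)c(O)\c2=N/c2ccc(C#N)cc2)cc1` reads > 30000 nM, which is a limit of the assay and not a number. Going by the values given here, compound 2 `COc1cc(C#N)ccc1/N=c1\c(O)c(O)\c1=N/[C@H](C)C(C)(C)C` gives 290 nM, the only actual number available in this assay, so it serves as the reference point here.

The next compound, compound 3 `C[C@@H](/N=c1\c(O)c(O)\c1=N/c1ccc(C#N)cc1Br)C(C)(C)C`, keeps the rest of compound 2 and changes one group: bromo in place of methoxy on an aromatic carbon. In words, this is bromo in place of methoxy on an aromatic carbon, at a place ortho to a large group and meta to a cyano group.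

Among the compounds with values here, no measured pair shows what this swap does on its own, so there is no direct precedent. The expectation therefore rests on compound 2 at 290 nM, with a wide margin to reflect how little is known. The expected step of a 1.2-fold lower number from compound 2 to compound 3 (0.06 log units; within the scatter) is not expected to exceed the usual scatter of repeated measurements, and no firm direction is predicted. For compound 3, the estimated value is 250 nM, with an expected range from 70 nM to 900 nM.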

Compound 3, half-maximal inhibitory concentration: 75 nM
Compound 3: middle estimate off by 3.3-fold (0.52 log units), on the high side, and the stated range covers the measured number.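

Bromo in place of methoxy on this aromatic carbon, ortho to a large group and meta to a cyano group, gives a 3.9-fold lower number from compound 2 to compound 3 (0.59 log units; beyond the scatter) in this assay. Going by these compounds alone, this is the first sign that the position matters in this assay, since a change of one group here moves the number by more than repeated measurements normally would, and it moves it towards a stronger inhibitor. It also shows that the oxygen of methoxy, the hydrogen-bond acceptor that leaves in this swap, is not required for inhibition in this series, and that bromo, with fewer heavy atoms, is well accepted at this place; nothing measured here says why the number moves.

A single step cannot separate what bromo adds from what the loss of methoxy removes, and chloro, fluoro or a plain hydrogen on the same carbon would begin to tell these apart. Going by these compounds, whether the same swap would act alike with a different group on the other side of the shared core also stays open, as compound 1 differs from compound 2 and compound 3 in more than one place.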